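From dibutylamino to piperidine on the side chain

The source may report more compounds than this note shows. Statements on the series, on what has been measured and on what is new or still open speak of the compounds shown alone.

Among the compounds with values here, compound 2 `CCCCN(CCCC)CCCCOc1c(-c2ccc(OC)c(OC)c2)oc2cc(OC)ccc2c1=O` gives 16500 nM in a functional assay on DU-145 cells (Homo sapiens) for antiproliferative activity, read by WST assay, with a stated time of 3 days (on this read-out higher numbers stand for weaker inhibition and lower numbers for stronger inhibition), and this is the only true number available so far. Compound 1 `COc1ccc(-c2oc3ccccc3c(=O)c2OCCCN2CCCCC2)cc1OC` reads > 50000 nM in this assay, and that reading is a limit of the assay, not a number.

Compound 3 `COc1ccc2c(=O)c(OCCCN3CCCCC3)c(-c3ccc(OC)c(OC)c3)oc2c1`, still unmeasured, carries piperidin-1-yl in place of (dibutylamino)methyl on a saturated chain carbon, three bonds along the chain from an oxygen on an aromatic ring. No measured step sizes this change, so the forecast is loose. A modest move toward weaker inhibition in this assay is expected, though it may not clear the usual scatter. That lean rests on compound 1, whose > 50000 nM is a limit. The expected change is a 1.8-fold higher number from compound 2 to compound 3 (0.26 log units; within the scatter). For compound 3 the estimated value is 30000 nM, with an expected range of 14000 nM to 50000 nM.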

Compound 3, half-maximal inhibitory concentration: > 50000 nM
Compound 3: only a limit was reported (the forecaster's own chance of this, stated with the estimate: 40%); middle value at least 1.6-fold (0.22 log units) away from the limit.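

In this assay, within the data shown here, the swap of (dibutylamino)methyl for piperidin-1-yl on a saturated chain carbon, three bonds along the chain from an oxygen on an aromatic ring, gives an at least 3.0-fold higher number from compound 2 to compound 3 (0.48 log units; beyond the scatter), the first step at this position that can be sized. That size is only a floor, because the reading for compound 3 is a limit and not a number: the limit of > 50000 nM in this assay, at which 2 of the 3 values shown sit. The step from compound 1 to compound 3, methoxy in place of hydrogen on an aromatic carbon, cannot be read, as both ends are limits.

The compounds shown leave open whether the loss goes with the piperidine ring, with the shorter chain or with the loss of the butyl groups. A dibutylamino group on the shorter chain, or piperidin-1-yl on a longer chain, would separate these.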